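A Chloro Group on the Five-Membered Ring

A few compounds are considered here, and "the series" means these few. Any claim that something is new, unique, unknown or untested is made for them only; others in the source may bear on it.

Of the compounds shown here, three built on a shared core have been tested in a functional assay on CCRF-CEM cells (Homo sapiens) for antiproliferative activity, with a stated time of 72 h; on this read-out higher numbers stand for weaker inhibition and lower numbers for stronger inhibition. Compound 1 `COc1ccc(-c2csc(=N)n2-c2ccc(OC)cc2)cc1` gives only a limit of the assay in this assay, > 20000 nM. This is the limit of > 20000 nM in this assay, at which 1 of the 3 values shown sits, and it is not a number. Compound 2 `COc1ccc(-n2c(-c3cc(OC)c(OC)c(OC)c3)csc2=N)cc1` gives 13200 nM in this assay. Compound 3 `COc1ccc(-c2csc(=O)n2-c2cc(OC)c(OC)c(OC)c2)cc1` gives 1800 nM in this assay, which is the lowest of the two numbers reported; compound 2 stands at a higher number, and the gap between the two lies beyond the usual scatter of repeated measurements.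

Compound 4 `COc1ccc(-c2c(Cl)sc(=O)n2-c2cc(OC)c(OC)c(OC)c2)cc1` has not yet been measured. It differs from compound 3 in one place: chloro in place of hydrogen on an aromatic carbon. Within the data shown here, no pair of measured compounds shows a step of this kind, so the data give no direct guide to its size. On the shared core, a small substituent entering at an aromatic carbon of the five-membered ring is expected to move the number only modestly, toward a slightly lower value, and probably within the scatter. Compound 3 serves as the anchor with 1800 nM. Compound 4 is therefore estimated at 1200 nM in this assay, with a likely range from 300 nM to 5000 nM. The expected step is a 1.5-fold lower number from compound 3 to compound 4 (0.18 log units; within the scatter).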

Compound 4, half-maximal inhibitory concentration: > 20000 nM
Compound 4: no number, only a limit; the forecaster's own chance of this, stated with the estimate: 5%; middle value at least 16-fold (1.22 log units) from the limit.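

In this assay, the aromatic carbon next to the ring sulfur proves to be a sensitive position on the shared core: chloro in place of hydrogen there gives an at least 11-fold higher number from compound 3 to compound 4 (1.04 log units; beyond the scatter). Among these compounds, the change adds only 1 heavy atom, and the earlier compounds offered no step of any kind, so nothing before this result indicated that this carbon of the five-membered ring, which is also next to the ring atom that bears a 4-methoxyphenyl group, could matter this much. Compound 4 gives only a limit of the assay and not a number, which leaves the step with a lower bound and no upper end: the limit of > 20000 nM in this assay, at which 2 of the 4 values shown sit.

On these data alone, whether the loss belongs to chloro itself or would follow any replacement of this hydrogen stays open, and a methyl group, a fluorine atom or an amine at the same carbon would help to separate the two. Also open, as far as these compounds go, is why the number rises at all, and whether chloro at this carbon would have a similar result on the core of compound 2.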